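The source may hold more compounds than are shown below. What is called first, only, known or untested is meant among the compounds shown, and "the series" means these compounds.

Compound 2 `CCCC(=O)OCCOC(=O)c1ccc(C(=O)Nc2ccc3c(c2)C(C)(C)CCC3(C)C)cc1` and compound 1 `CCCC(=O)OCCCCOC(=O)c1ccc(C(=O)Nc2ccc3c(c2)C(C)(C)CCC3(C)C)cc1` give numbers within the scatter of each other in a functional assay on HL-60 cells (Homo sapiens) for inhibition, read by MTT assay, with a stated time of 48 h; a lower number here means a stronger inhibitor, a higher number a weaker inhibitor: compound 2 gives 6290 nM, and compound 1 gives 7320 nM, so that the step of a 1.2-fold lower number from compound 1 to compound 2 (0.07 log units; within the scatter) shows no real difference. Compound 3 `CCCC(CCC)C(=O)OCCOC(=O)c1ccc(C(=O)Nc2ccc3c(c2)C(C)(C)CCC3(C)C)cc1` differs from compound 2 by 1-propylbutyl in place of propyl on a carbonyl carbon, on a carbonyl carbon whose other neighbour is an oxygen next to a carbonyl group. Among the measured compounds shown here, no measured step touches the group on that carbonyl carbon; the single step available concerns a saturated chain carbon elsewhere in the molecule and was itself within the scatter. For the measured compounds named here, there is therefore nothing among the measured compounds to point to a shift beyond the scatter in this assay, in either direction. Compound 3 is accordingly expected to give about 6300 nM in this assay, within a range of 2500 nM to 16000 nM. The step of a 1.0-fold higher number from compound 2 to compound 3 (0.00 log units; within the scatter) that this estimate implies is expected to lie within the scatter.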

Compound 3, half-maximal inhibitory concentration: 256000 nM
Estimate against measurement, compound 3: 41-fold (1.61 log units) below, outside the stated range (above it).
By their numbers in this assay, from the lowest: compounds 2 and 1 (each within the scatter of the next); then compound 3.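

In this assay, the group on the carbonyl carbon proves to be a sensitive place, unlike the chain change seen earlier, which stayed within the scatter: 1-propylbutyl in place of propyl gives a 41-fold higher number from compound 2 to compound 3 (1.61 log units; beyond the scatter). The comparison with the longer-chain propyl ester points the same way, with a 35-fold higher number from compound 1 to compound 3 (1.54 log units; beyond the scatter), so compound 3 stands well apart from both compounds carrying propyl. Nothing available explains this sharp loss of inhibition.

The compounds shown leave open whether the loss follows the branching of 1-propylbutyl or only its carbon count, which a straight heptyl chain or an isopropyl group on that carbonyl carbon would help to separate. Also open, from the compounds shown here alone, is whether 1-propylbutyl has the same effect on the longer chain of compound 1.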